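Chain length at the amide-type nitrogen: compound 2 to compound 3

This account rests on a few compounds, and the source may have more. Where it says the series, first, only, none or still open, it means among the compounds named here.

The series is followed in a functional assay on HT-1080 cells (Homo sapiens) for antiproliferative activity, read by sulforhodamine B assay, with a stated time of 48 h; on this read-out lower numbers stand for stronger inhibition and higher numbers for weaker inhibition. Compound 1 `O=C(CCCl)Nc1ccc(S(=O)(=O)Oc2ccccc2I)cc1` gives 4200 nM and compound 2 `CCCNC(=O)Nc1ccc(S(=O)(=O)Oc2ccccc2I)cc1` gives 700 nM. Among the compounds with values here, the only measured step is a 6.0-fold lower number from compound 1 to compound 2 (0.78 log units; beyond the scatter). Compound 2 thus stands with the lowest of the two numbers; its nearest neighbour is compound 1, above it by that step.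

Compound 3 `CCCCCNC(=O)Nc1ccc(S(=O)(=O)Oc2ccccc2I)cc1` differs from compound 2 by ethyl in place of hydrogen on a saturated chain carbon, three bonds along the chain from an amide-type nitrogen. Within the data shown here, no measured step touches the chain at the amide-type nitrogen: the step from compound 1 to compound 2 exchanges the whole group on the carbonyl carbon, so it says nothing about lengthening this chain. In this assay the change is therefore expected to give a step within the scatter, a 1.2-fold lower number from compound 2 to compound 3 (0.07 log units; within the scatter), with no direction readable from the two measured compounds. Compound 3 is estimated at 600 nM, in the range 200 nM to 1800 nM.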

Compound 3, half-maximal inhibitory concentration: 6900 nM
Beside the measured number, compound 3's estimate is 12-fold (1.06 log units) below it, and the stated range ends below it.
By their numbers in this assay, from the lowest: compound 2; then compounds 1 and 3 (each within the scatter of the next).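

In this assay, within the data shown here, the chain at the amide-type nitrogen proves sensitive to length: ethyl in place of hydrogen on the propyl chain, which makes it pentyl, gives a 9.9-fold higher number from compound 2 to compound 3 (0.99 log units; beyond the scatter) and is the only measured step at this position. The advantage of compound 2 is lost with this extension, and the pentylamino group cannot be told apart from the 2-chloroethyl group on the carbonyl carbon (a 1.6-fold higher number from compound 1 to compound 3 (0.22 log units; within the scatter)). Nothing shown offers an explanation for this loss at the longer chain.

From the compounds shown here alone, how the number behaves with a butyl chain remains open, as does whether an ethyl chain, or a chain ending in an amine or a carboxylic acid, would retain the number of compound 2. With only the propyl and pentyl chains compared here, no trend in chain length can be drawn.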